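This account rests on a few compounds, and the source may have more. Where it says the series, first, only, none or still open, it means among the compounds named here.

Notes on the series. Compound 1 `COc1ccc(/C=C/c2ccc3ccccc3c2)cc1` in a functional assay on HT-29 cells (Homo sapiens) for inhibition (a higher number here means a weaker inhibitor, a lower number a stronger inhibitor), gives > 5000 nM, which is a limit of the assay and not a number. Compound 2 `COc1cccc(/C=C\c2ccc3ccccc3c2)c1` has the same atoms as compound 1 joined differently; the difference between the two cores is not broken down here. In this assay, among the compounds with values here, compound 2 gives 1920 nM, the only number among the values so far. Compound 3 `COc1ccc(/C=C/c2ccc3ccccc3c2)cc1F` carries the change (fluoro in place of hydrogen on an aromatic carbon). In this assay compound 3 gives > 5000 nM, again a limit of the assay. The step that the two limits leave unreadable from compound 1 to compound 3 is unreadable due to the limit of > 5000 nM in this assay, at which 2 of the 3 values shown sit. Compound 4 `COc1cc(/C=C\c2ccc3ccccc3c2)ccc1F` carries the same kind of change relative to compound 2, (fluoro in place of hydrogen on an aromatic carbon); the place differs only in that the fluoro here sits para to a large group rather than meta to a large group. Since the measured step yields no size, the expectation for compound 4 rests on compound 2 at 1920 nM alone, and a step of a 1.1-fold higher number from compound 2 to compound 4 (0.04 log units; within the scatter) within the usual scatter is expected. Compound 4 is estimated at 2100 nM, with a range from 700 nM to 6000 nM.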

Compound 4, half-maximal inhibitory concentration: 450 nM
Compound 4: the middle estimate sits 4.7-fold (0.67 log units) above what was measured, and the stated range ends above it.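

In this assay, fluoro in place of hydrogen on an aromatic carbon, ortho to a methoxy group and para to a large group, gives a 4.3-fold lower number from compound 2 to compound 4 (0.63 log units; beyond the scatter). The same kind of change on the core of compound 1, the step to compound 3, cannot be read, due to the assay limit at both of its ends: the limit of > 5000 nM in this assay, at which 2 of the 4 values shown sit. The result therefore holds for the core of compound 2 at this one place, and it does not show that the change carries over to another core, nor how large it would be there.

The compounds shown leave open whether another group at this same place, such as chloro, an amine or a carboxylic acid, would give a step like that of fluoro, and whether a longer chain in place of the methoxy group would keep compound 4 at 450 nM. Also open, on these data alone, is whether the step seen in this assay recurs on other cell lines.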